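A hydroxypyrimidine in place of pyridine on the sulfoxide arm

This account rests on a few compounds, and the source may have more. Where it says the series, first, only, none or still open, it means among the compounds named here.

Compounds measured in an assay on HEK293 cells for inhibition of sodium-dependent dopamine transporter (Homo sapiens), read by scintillation counting, with stated times of 5 min and 1 min; a higher number here means a weaker inhibitor, a lower number a stronger inhibitor:
compound 1 `[O-][S+](Cc1ccc(Cl)s1)C(c1ccccc1)c1ccccc1` gives 12800 nM
compound 2 `Cc1cnc(C[S+]([O-])C(c2ccccc2)c2ccccc2)nc1` gives 156000 nM
compound 3 `[O-][S+](Cc1ccncc1)C(c1ccccc1)c1ccccc1` gives 63500 nM

Compound 3 stands second highest of the three numbers in this assay. The steps of a 2.5-fold lower number from compound 2 to compound 3 (0.39 log units; beyond the scatter) and a 5.0-fold higher number from compound 1 to compound 3 (0.70 log units; beyond the scatter) place it between the other two, both gaps lying beyond the scatter.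

Compound 4 `Cc1nc(O)cc(C[S+]([O-])C(c2ccccc2)c2ccccc2)n1` has not yet been measured. Its change from compound 3 is 6-hydroxy-2-methylpyrimidin-4-yl in place of pyridin-4-yl on a saturated chain carbon bound to a sulfur. Going by the values given here, two measured steps bear on it. The closest is a 2.5-fold lower number from compound 2 to compound 3 (0.39 log units; beyond the scatter), which runs in the opposite direction to the present change: read backwards, moving from a pyridin-4-yl to a pyrimidine group gave a modest rise in the number. The other is a 12-fold higher number from compound 1 to compound 2 (1.09 log units; beyond the scatter), a large rise when a pyrimidine replaced the thiophene. Among the compounds with values here, no measured step covers the hydroxy group or the shift of the methyl group, so that part of the change is unknown here. On the evidence of the pyrimidine steps, a modest rise in the number, in the direction of weaker inhibition, is expected: a 2.4-fold higher number from compound 3 to compound 4 (0.37 log units; beyond the scatter). Compound 4 is therefore estimated at 150000 nM in this assay, within a range from 50000 nM to 450000 nM.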

Compound 4, half-maximal inhibitory concentration: 3100 nM
Compound 4: middle estimate off by 48-fold (1.68 log units), on the high side; the whole stated range lies above it.
By their numbers in this assay, from the lowest: compound 4; then compound 1; then compound 3; then compound 2.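

In this assay, going by these compounds alone, the place on a saturated chain carbon bound to a sulfur turned out to tolerate a pyrimidine far better than the earlier compounds suggested: 6-hydroxy-2-methylpyrimidin-4-yl in place of pyridin-4-yl gave a large gain (a 20-fold lower number from compound 3 to compound 4 (1.31 log units; beyond the scatter)), and the same group far outdid 5-methylpyrimidin-2-yl (a 50-fold lower number from compound 2 to compound 4 (1.70 log units; beyond the scatter)), so the pyrimidine ring alone does not set the direction of the change and the way it is substituted and attached matters greatly. Within the data shown here, the 5-chlorothiophen-2-yl group, which had held the lowest number among the earlier compounds, also gave way (a 4.1-fold lower number from compound 1 to compound 4 (0.62 log units; beyond the scatter)), leaving the new group as the strongest inhibitor of the four. Nothing available explains why this group lowers the number so sharply.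

The compounds shown do not separate the contribution of the hydroxy group from that of the methyl group or from the point of attachment of the ring. On these data alone, whether a methoxy group or an amine in place of the hydroxy group would keep this gain also remains open.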